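One Group Exchanged on a Long Chain

The compounds below may be only part of what the source reports. "The series", "measured", "known", "first", "only" and "open" are said of these compounds alone.

Compound 1 `COC(=O)[C@H](O)C/C(C)=C\CC[C@H](C)/C=C/C=C(\C)CCCC1=CC(=O)O[C@H]1O` gives 10.9 ug/mL
Compound 2 `COC1C=C(CCC/C(C)=C/C=C/[C@@H](C)CC/C=C(/C)C[C@H]2OC(=O)C(C)=C2O)C(=O)O1` gives 10.9 ug/mL

In a functional assay on SK-MEL-2 cells (Homo sapiens) for cytotoxicity (on this read-out lower numbers stand for an effect already at smaller amounts and higher numbers for an effect only at larger amounts of compound), compound 2 gives 10.9 ug/mL and so stands level with compound 1 at the digits shown, within the usual scatter of such measurements.

Compound 3 `CC1=C(O)[C@@H](C/C(C)=C\CC[C@H](C)/C=C/C=C(\C)CCCC2=CC(=O)N(CC(=O)O)C2)OC1=O` has not yet been measured. Compared with compound 2 it carries a group of 10 heavy atoms (6 carbon, 1 nitrogen, 3 oxygen; one five-membered non-aromatic ring with 1 hetero atom) in place of a group of 8 heavy atoms (5 carbon, 3 oxygen; one five-membered non-aromatic ring with 1 hetero atom), on a saturated chain carbon, three bonds along the chain from a double-bonded chain carbon and this is the one place where the two differ. The entering group brings a nitrogen that the leaving group lacks, and neither group has a net charge.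

Within the data shown here, no measured step shows what such an exchange does in this assay so its size cannot be read directly from the data. Compound 1 at 10.9 ug/mL has a different structure from compound 2 at 10.9 ug/mL yet the two sit level, so a large step is not expected. A small move toward higher numbers, possibly within the scatter, is the expectation.

The estimate means a 1.3-fold higher number from compound 2 to compound 3 (0.11 log units; within the scatter) as the expected step. In this assay compound 3 is estimated at 14 ug/mL with an expected range from 6 ug/mL to 30 ug/mL for repeated measurements.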

Compound 3, concentration for half-maximal effect: > 30 ug/mL
Compound 3: only a limit was reported; the forecaster's own chance of this, stated with the estimate: 15%; at least 2.1-fold (0.33 log units) between middle value and limit.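

In this assay compound 3 gives > 30 ug/mL, and this value is a limit of the assay rather than a number: the limit of > 30 ug/mL in this assay, at which 1 of the 3 values shown sits.

Even so, this gives the first measured step at this place, the saturated chain carbon three bonds along the chain from a double-bonded chain carbon: putting the group of 10 heavy atoms, with its nitrogen, in place of the group of 8 heavy atoms gives an at least 2.7-fold higher number from compound 2 to compound 3 (0.43 log units; beyond the scatter). Among these compounds, compound 1 and compound 2 offered no step of this kind, whereas this result shows that the exchange at this one place can move the read-out beyond the usual scatter.

The compounds shown leave open how far the true number for compound 3 lies past the limit, and which part of the entering group goes with the step. A compound with a methyl group on the ring nitrogen in place of the side chain ending in a carboxylic acid would help separate the contribution of the nitrogen from that of the carboxylic acid.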